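Replacing a Phenolic Hydroxy with Methylsulfanyl: Cytotoxicity Outlook

The source may report more compounds than this note shows. Statements on the series, on what has been measured and on what is new or still open speak of the compounds shown alone.

Compound 1 `O=C(COc1cccc2ccccc12)N/N=C/c1ccc(O)cc1`: 20 ug/mL
Compound 2 `COc1cc(/C=N/NC(=O)COc2cccc3ccccc23)cc(OC)c1O`: 100 ug/mL

In an ADME assay on HEL cells (Homo sapiens) for cytotoxicity (a lower number here means that less compound is tolerated, a higher number that more compound is tolerated), compound 1 gives 20 ug/mL, the lower of the two numbers, while compound 2 gives 100 ug/mL, a gap that lies beyond the usual scatter. Compound 3 `CSc1ccc(/C=N/NC(=O)COc2cccc3ccccc23)cc1` differs from compound 1 by one change: methylsulfanyl in place of hydroxy on an aromatic carbon. For the measured compounds named here, no measured pair carries this same change, so nothing shows how it moves the tolerated concentration. In this assay the estimated step is a 2.0-fold higher number from compound 1 to compound 3 (0.30 log units; within the scatter), expected to be small, upward at most, and possibly within the scatter. Compound 3 is therefore expected to give about 40 ug/mL, with a range from 15 ug/mL to 100 ug/mL.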

Compound 3, minimum cytotoxic concentration: >= 100 ug/mL
Compound 3 ended at the assay's limit (the forecaster's own chance of this, stated with the estimate: 25%); middle value at least 2.5-fold (0.39 log units) from the limit.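

In this assay, methylsulfanyl in place of hydroxy on this aromatic carbon gives an at least 5.0-fold higher number from compound 1 to compound 3 (0.69 log units; beyond the scatter), the first measured case of this change and of a compound without a hydroxy on this ring. Removing the hydroxy therefore does not lower the tolerated concentration in this pair. Compound 3 stands at a limit of the assay rather than at a number: the limit of >= 100 ug/mL in this assay, at which 1 of the 3 values shown sits.

As far as these compounds go, how far compound 3 lies past that limit remains open. So does whether an amine or a longer chain such as ethylsulfanyl at this position would give a similar step.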